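The compounds below may be only part of what the source reports. "The series", "measured", "known", "first", "only" and "open" are said of these compounds alone.

Measured so far:
Compound 1, `Clc1ccc(C2CC(c3ccccc3)=NN2c2ccc(-c3ccccc3)nn2)cc1`, gives 100000 nM in a functional assay on MCF7 cells (Homo sapiens) for antiproliferative activity, read by MTT assay, with a stated time of 24 h; on this read-out lower numbers stand for stronger inhibition and higher numbers for weaker inhibition.
Compound 2, `COc1ccc(C2CC(c3ccccc3)=NN2c2ccc(-c3ccccc3)nn2)cc1`, gives 100000 nM.
Compound 3, `Clc1ccc(C2=NN(c3ccc(-c4ccccc4)nn3)C(c3ccccc3)C2)cc1`, gives 10000 nM.

Compounds 1 and 3 are built from the same atoms joined differently; the difference between the two cores is not broken down here. Compound 1 and compound 2 differ by methoxy in place of chloro on an aromatic carbon, and that change made no change at the digits printed from compound 1 to compound 2 (within the scatter). Compound 4, `COc1ccc(C2=NN(c3ccc(-c4ccccc4)nn3)C(c3ccccc3)C2)cc1`, has not been measured; it differs from compound 3 by methoxy in place of chloro on an aromatic carbon, the same change at the same kind of place. Since that change left the read-out unmoved from compound 1 to compound 2, compound 4 is expected to stay close to compound 3, with an expected step of no change at the digits printed from compound 3 to compound 4 (within the scatter). The estimate for compound 4 is therefore 10000 nM, expected to lie between 4000 nM and 30000 nM.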

Compound 4, half-maximal inhibitory concentration: > 100000 nM
Compound 4: only a limit was reported; the forecaster's own chance of this, stated with the estimate: 10%; middle value at least 10-fold (1.00 log units) from the limit.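

In this assay, putting methoxy in place of chloro gave an at least 10-fold higher number from compound 3 to compound 4 (1.00 log units; beyond the scatter), so this change did not carry over unchanged from one core to the other: the same change on two cores in this assay, no change at the digits printed (within the scatter) from compound 1 to compound 2 and an at least 10-fold higher number (1.00 log units; beyond the scatter) from compound 3 to compound 4, at least 10-fold (1.00 log units) apart, beyond the scatter of two such steps

For compound 4, the reading of > 100000 nM is a limit of the assay and not a number: the limit of > 100000 nM in this assay, at which 1 of the 4 values shown sits.

The result therefore does not give the exact size of the step on the core of compound 3, does not explain why the two cores differ, and, with one pair on each core, sets no rule for other cores.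

On these data alone, it remains open how other groups at this place on the ring, such as an amine, a carboxylic acid or a longer ethoxy chain, would behave on each core.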